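From Propoxy to Ethylamino on the Carbonyl Carbon

The source may report more compounds than this note shows. Statements on the series, on what has been measured and on what is new or still open speak of the compounds shown alone.

In a functional assay on NTUB1 cells (Homo sapiens) for cytotoxicity, read by MTT assay, with a stated time of 72 h (on this read-out lower numbers stand for stronger inhibition and higher numbers for weaker inhibition), compound 2 `CCCOC(=O)c1ccc(/C=C/C(=O)c2cc(OC)ccc2OC)cc1` gives 6010 nM. Compound 1 `CCOC(=O)c1ccc(/C=C/C(=O)c2cc(OC)ccc2OC)cc1` gives 4490 nM, and the step is a 1.3-fold higher number from compound 1 to compound 2 (0.13 log units; within the scatter), so these two share the upper end of the numbers. Compound 3 `CNC(=O)c1ccc(/C=C/C(=O)c2cc(OC)ccc2OC)cc1` gives 2200 nM. Compound 4 `CCNC(=O)c1ccc(/C=C/C(=O)c2cc(OC)ccc2OC)cc1` remains unmeasured and differs from compound 2 thus: ethylamino in place of propoxy on a carbonyl carbon. The closest evidence is the modest 2.7-fold lower number from compound 2 to compound 3 (0.44 log units; beyond the scatter), with methylamino in place of propoxy, supported by the modest 2.0-fold lower number from compound 1 to compound 3 (0.31 log units; beyond the scatter). Within the data shown here, no measured step compares ethylamino with methylamino. The expected change is therefore similar in size and direction, a 2.2-fold lower number from compound 2 to compound 4 (0.35 log units; beyond the scatter). For compound 4 the estimated value is 2700 nM, with an expected range of 1300 nM to 5500 nM.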

Compound 4, half-maximal inhibitory concentration: 3760 nM
The estimate for compound 4 lay 1.4-fold (0.14 log units) below the measured number, within the range that was stated.
By their numbers in this assay, from the lowest: compounds 3, 4, 1 and 2 (each within the scatter of the next, the first and the last beyond it).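

In this assay, ethylamino on this carbonyl carbon does not separate from propoxy (a 1.6-fold lower number from compound 2 to compound 4 (0.20 log units; within the scatter)) or from ethoxy (a 1.2-fold lower number from compound 1 to compound 4 (0.08 log units; within the scatter)), so the gap seen with methylamino does not recur with this amide. Methyl in place of hydrogen on the chain of the amide also leaves the two compounds unseparated (a 1.7-fold higher number from compound 3 to compound 4 (0.23 log units; within the scatter)). This change reads alike on the ester and the amide: the same change on two cores in this assay, a 1.3-fold higher number (0.13 log units; within the scatter) from compound 1 to compound 2 and a 1.7-fold higher number (0.23 log units; within the scatter) from compound 3 to compound 4, 1.3-fold (0.11 log units) apart, within the scatter of two such steps.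

The compounds shown leave open how butylamino or a carboxylic acid on this carbonyl carbon would read in this assay.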